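Dimethylamino for trifluoromethyl on the aryl hydrazone

A few compounds are considered here, and "the series" means these few. Any claim that something is new, unique, unknown or untested is made for them only; others in the source may bear on it.

Measured so far:
compound 1 `Cc1c(C(=O)N/N=C/c2ccc([N+](=O)[O-])s2)no[n+]1[O-]`: 68000 nM
compound 2 `Cc1c(C(=O)N/N=C/c2ccc(C(F)(F)F)cc2)no[n+]1[O-]`: > 400000 nM

Both compounds share one core and were tested in an ADME assay on J744 cells (Mus musculus) for cytotoxicity, read by MTT assay, with a stated time of 48 h; a lower number here means a stronger inhibitor, a higher number a weaker inhibitor. Compound 1 gives 68000 nM. For compound 2 the assay reports no number but only a limit, > 400000 nM. Compound 2 thus stands at the limit of > 400000 nM in this assay, at which 1 of the 2 values shown sits.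

Compound 3 `Cc1c(C(=O)N/N=C/c2ccc(N(C)C)cc2)no[n+]1[O-]` is not yet measured. It differs from compound 2 in one place: dimethylamino in place of trifluoromethyl on an aromatic carbon. Among the compounds with values here, no measured step guides this change, so a step no larger than the scatter is expected, a number no higher from compound 2 to compound 3 (the limit leaves the size open), and compound 3 is expected to remain weak. Compound 3 is estimated at 400000 nM, ranging from 150000 nM to 1500000 nM.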

Compound 3, half-maximal inhibitory concentration: 129000 nM
Compound 3: middle estimate off by 3.1-fold (0.49 log units), on the high side, outside the stated range (below it).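

In this assay, dimethylamino in place of trifluoromethyl on this aromatic carbon gives an at least 3.1-fold lower number from compound 2 to compound 3 (0.49 log units; beyond the scatter), so the group at this place can change the reading. Compound 3 gives a real number on the six-membered aromatic ring, 129000 nM. The full size of the step stays unknown since compound 2 has only a limit: the limit of > 400000 nM in this assay, at which 1 of the 3 values shown sits.

A single pair cannot tell whether the change comes from losing trifluoromethyl or from gaining dimethylamino. The compounds shown also leave open how a plain hydrogen, a primary amine or a carboxylic acid on this carbon would read.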